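This account rests on a few compounds, and the source may have more. Where it says the series, first, only, none or still open, it means among the compounds named here.

In an ADME assay on microsomes from liver (Homo sapiens) for pharmacokinetics, read by LC-MS, with a stated time of 60 min, tested at 1 uM (a lower number here means slower removal, a higher number faster removal of the compound), compound 1 (`O=C(NCc1ccc(S(=O)(=O)C2CCCCC2)cc1)N1Cc2ccncc2C1`) gives 16 mL/min/kg and compound 2 (`O=C(NCc1ccc(S(=O)(=O)C2CCCOC2)cc1)N1Cc2ccncc2C1`) gives 7 mL/min/kg on the same shared core, the two differing only in the group on a sulfonyl sulfur. Compound 3 (`O=C(NCc1ccc(S(=O)(=O)N2CC3(CCOCC3)C2)cc1)N1Cc2ccncc2C1`) carries a third group at that place and gives 13 mL/min/kg in this test, which puts it within the scatter of both others.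

Compound 4 (`O=C(NCc1ccc(S(=O)(=O)N2CCC(N3CCCC3)CC2)cc1)N1Cc2ccncc2C1`) differs from compound 3 in one place only (a group of 11 heavy atoms (9 carbon, 2 nitrogen; one five-membered non-aromatic ring with 1 hetero atom, one six-membered non-aromatic ring with 1 hetero atom) in place of a group of 9 heavy atoms (7 carbon, 1 nitrogen, 1 oxygen; one four-membered non-aromatic ring with 1 hetero atom, one six-membered non-aromatic ring with 1 hetero atom), on a sulfonyl sulfur). Among the measured compounds shown here, the group that enters is 4-(pyrrolidin-1-yl)piperidin-1-yl, and no measured compound carries it, so the data offer no direct reading of this group.

Three measured swaps at the same sulfur bear on the change. The largest is a 2.3-fold lower number from compound 1 to compound 2 (0.36 log units; beyond the scatter) and counts as modest, while a 1.2-fold lower number from compound 1 to compound 3 (0.09 log units; within the scatter) and a 1.9-fold higher number from compound 2 to compound 3 (0.27 log units; within the scatter) both stay within the scatter. With compound 2 and compound 1 marking that largest step (a 2.3-fold lower number from compound 1 to compound 2 (0.36 log units; beyond the scatter)), no step beyond the scatter is expected in this assay for the new group, although one of that modest size cannot be ruled out. The expected step is small (a 1.1-fold higher number from compound 3 to compound 4 (0.03 log units; within the scatter)). The estimate for compound 4 is 14 mL/min/kg within an expected range (7 mL/min/kg to 28 mL/min/kg).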

Compound 4, clearance in the Homo sapiens assay: 6 mL/min/kg
The estimate for compound 4 lay 2.3-fold (0.37 log units) above the measured number; measured number below the stated range.
By their numbers in the Homo sapiens assay, from the lowest: compounds 4, 2, 3 and 1 (each within the scatter of the next, the first and the last beyond it).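

In the Homo sapiens assay, 4-(pyrrolidin-1-yl)piperidin-1-yl on the sulfonyl sulfur gives the first step away from compound 3 that lies beyond the scatter (a 2.2-fold lower number from compound 3 to compound 4 (0.34 log units; beyond the scatter)), so this position can move the number more than the swaps to compound 3 had suggested. In the Homo sapiens assay, the new group also lies beyond the scatter when set against cyclohexyl (a 2.7-fold lower number from compound 1 to compound 4 (0.43 log units; beyond the scatter)), yet it stays within the scatter when set against oxan-3-yl (a 1.2-fold lower number from compound 2 to compound 4 (0.07 log units; within the scatter)), which places compound 4 with compound 2 at the slow-removal end of this small set. In a physicochemical assay for solubility, in phosphate buffer, with a stated time of 24 h, at pH 7.4, tested at 100 uM (on this read-out lower numbers stand for lower solubility and higher numbers for higher solubility), compound 3 gives 272000 nM and compound 4 gives 6200 nM. The same swap also comes with a large drop in the physicochemical assay, a change in a second property that the earlier clearance numbers could not reveal: the measured solubility of compound 3, 272000 nM, and of compound 4, 6200 nM, a 44-fold lower number (1.64 log units; beyond the scatter)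

The compounds shown leave open which part of the new group goes with these two changes, the pyrrolidine ring or the piperidine ring, and a plain piperidin-1-yl on the same sulfur would help to separate them. They also leave open whether a morpholin-4-yl group, with an oxygen in its ring, would keep the low number in the Homo sapiens assay while giving a higher number in the physicochemical assay.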